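This account rests on a few compounds, and the source may have more. Where it says the series, first, only, none or still open, it means among the compounds named here.

Measured compounds:
compound 1, `COc1ccc(C(=O)/C=C/c2cccc(F)c2)c2c1C=CC(C)(C)O2`: > 10000 nM
compound 2, `COc1ccc(C(=O)/C=C/c2ccc(N(c3ccccc3)c3ccccc3)cc2)c2c1C=CC(C)(C)O2`: > 10000 nM
compound 3, `COc1ccc(C(=O)/C=C/c2ccc3ccccc3n2)c2c1C=CC(C)(C)O2`: 4530 nM

All three compounds share one core and differ only in the aryl group carried on the chain. In a functional assay on HCT-116 cells (Homo sapiens) for antiproliferative activity, read by MTT assay, with a stated time of 24 h (on this read-out lower numbers stand for stronger inhibition and higher numbers for weaker inhibition), compound 1 gives > 10000 nM, which is a limit of the assay and not a number. Compound 2 likewise reaches only the limit of > 10000 nM in this assay. Compound 3 is the only one of the three with a measured number, 4530 nM in this assay. Compound 1 thus stands at the weak end of what is shown, at the limit of > 10000 nM in this assay, at which 2 of the 3 values shown sit, so no step between measured compounds can be drawn from it.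

Compound 4, `COc1ccc(C(=O)/C=C/c2ccc([N+](=O)[O-])cc2)c2c1C=CC(C)(C)O2`, is not yet measured. It differs from compound 1 in one place: 4-nitrophenyl in place of 3-fluorophenyl on a double-bonded chain carbon bound to a double-bonded chain carbon. Among the measured compounds shown here, nothing among the measured compounds tells how a 4-nitrophenyl group behaves in this assay; the one compound with a number, compound 3, carries a different ring altogether. The expected step is an at least 1.1-fold lower number from compound 1 to compound 4 (0.04 log units; that floor lies within the scatter), which is taken as none beyond the scatter, since compound 1 itself sits at a limit. On that basis compound 4 is expected to give about 9000 nM in this assay, within a range from 3000 nM to 30000 nM.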

Compound 4, half-maximal inhibitory concentration: 8880 nM
Compound 4: the middle estimate sits 1.0-fold (0.01 log units) above what was measured; the range from low to high includes it.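

Among the compounds shown, compound 4 is the first with a single six-membered carbon ring at this place to give a measured number, with 8880 nM in this assay; the only other number comes from the different ring of compound 3. Replacing 3-fluorophenyl with 4-nitrophenyl on a double-bonded chain carbon bound to a double-bonded chain carbon gives an at least 1.1-fold lower number from compound 1 to compound 4 (0.05 log units; that floor lies within the scatter), so this change can be bounded only by a floor and is not shown to exceed the scatter. The true size of the change cannot be read because compound 1 has only a limit and not a number: the limit of > 10000 nM in this assay, at which 2 of the 4 values shown sit.

The compounds shown do not separate the exchange of fluorine for a nitro group from the shift in where the substituent stands on the ring, and a 3-nitrophenyl or a 4-fluorophenyl group would be needed to tell these apart. They also leave open how a 4-aminophenyl or a 4-carboxyphenyl group would behave at this place in this assay.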